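The source may report more compounds than this note shows. Statements on the series, on what has been measured and on what is new or still open speak of the compounds shown alone.

Compound 1 `C=C1CC[C@@H]2[C@](C)(CO)[C@H](O)CC[C@@]2(C)[C@@H]1CCC1=CCOC1=O` and compound 2 `C=C1CC[C@@H]2[C@](C)(CO)[C@H](O)CC[C@@]2(C)[C@@H]1C/C=C1\C=COC1=O` share the same core and differ only in the side chain that carries the lactone. In a functional assay on NIH3T3 cells (Mus musculus) for inhibition, read by MTT assay, with a stated time of 72 h (on this read-out higher numbers stand for weaker inhibition and lower numbers for stronger inhibition), compound 1 gives 176000 nM, a weak result. Among the measured compounds shown here, compound 2 is reported in this assay as "not active" (no number reported), so no number stands for it and its position can only be described as at the inactive end of what has been seen here; no step to compound 1 can be given. Compound 3 `C=C1CC[C@H]2[C@@](C)(CC[C@@H](O)[C@@]2(C)C(=O)OCc2ccccc2)[C@@H]1C/C=C1\C=COC1=O` keeps the side chain of compound 2 and changes the core: benzyloxycarbonyl in place of hydroxymethyl on a saturated ring carbon. For the measured compounds named here, with compound 2 recorded as inactive, there is no measured step from which the size of this change can be read, and nothing in the two measured compounds shows that the side chain of compound 2 can be turned active by a change elsewhere. Compound 3 is therefore expected to remain weak in this assay, with a fair chance that only a limit is reported. Compound 3 is estimated at 120000 nM, in a range from 20000 nM to 600000 nM.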

Compound 3, half-maximal inhibitory concentration: 177000 nM
The estimate for compound 3 lay 1.5-fold (0.17 log units) below the measured number; the measured number falls inside the stated range.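

Among the compounds shown here, compound 2 carries no number in this assay, so no step from it to compound 3 can be read, although compound 3 gives 177000 nM. The compounds shown leave open how much the exchange of hydroxymethyl for benzyloxycarbonyl changes inhibition on its own. Nothing shown bears on the reason for this result.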